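Chloro-to-hydrogen step on the shared core, second occurrence

The source may hold more compounds than are shown below. What is called first, only, known or untested is meant among the compounds shown, and "the series" means these compounds.

Compound 1 `ClCc1ccc(Cn2cnc3c(Cl)ncnc32)cc1` gives 1820 nM in a functional assay on NCI-H322M cells (Homo sapiens) for cytotoxicity, read by sulforhodamine B assay, with a stated time of 48 h; on this read-out lower numbers stand for stronger inhibition of growth and higher numbers for weaker inhibition of growth. Compound 2 `ClCc1ccc(Cn2cnc3nc(Cl)nc(Cl)c32)cc1` gives 670 nM, the lowest of the three measured values, and compound 3 `ClCc1ccc(Cn2cnc3c(Cl)nc(Cl)nc32)cc1` gives 12600 nM. The cores of compound 2 and compound 3 are built from the same atoms joined differently; the difference between the two cores is not broken down here. The change hydrogen in place of chloro on an aromatic carbon gave a 6.9-fold lower number from compound 3 to compound 1 (0.84 log units; beyond the scatter).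

Compound 4 `ClCc1ccc(Cn2cnc3ncnc(Cl)c32)cc1` remains to be measured. It differs from compound 2 by hydrogen in place of chloro on an aromatic carbon, the same change at the same kind of place as that from compound 3 to compound 1. Resting on the step seen for compound 1 against compound 3, a 6.9-fold lower number from compound 3 to compound 1 (0.84 log units; beyond the scatter), a step of similar direction, a 4.5-fold lower number from compound 2 to compound 4 (0.65 log units; beyond the scatter), is expected for compound 4, though on a core whose response to this change is not yet known. Compound 4 is therefore estimated at 150 nM, with a range from 60 nM to 500 nM.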

Compound 4, concentration for 50% growth inhibition: 1620 nM
For compound 4 the middle estimate is 11-fold (1.03 log units) below the measured one; measured number outside the range, above it.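

In this assay, hydrogen in place of chloro on the aromatic carbon between two ring nitrogen atoms gave a 2.4-fold higher number from compound 2 to compound 4 (0.38 log units; beyond the scatter). Set beside the earlier step, the same change does not carry from one core to the other, even in direction: the same change on two cores in this assay, a 6.9-fold lower number (0.84 log units; beyond the scatter) from compound 3 to compound 1 and a 2.4-fold higher number (0.38 log units; beyond the scatter) from compound 2 to compound 4, 17-fold (1.22 log units) apart, beyond the scatter of two such steps. A step read on one of these cores therefore gives no safe guide to the other, but these two pairs do not show what in the cores sets the difference, nor how a third core would respond.

The compounds shown leave open how an amine or a methoxy group would compare with chloro or hydrogen at that carbon on each core. Also open, on these data alone, is what a hydroxymethyl group in place of the chloromethyl group would do to these numbers.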